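The source may report more compounds than this note shows. Statements on the series, on what has been measured and on what is new or still open speak of the compounds shown alone.

Measured in a functional assay on Huh-7 cells (Homo sapiens) for cytotoxicity, read by MTT assay, with a stated time of 72 h; a higher number here means that more compound is tolerated, a lower number that less compound is tolerated:
- compound 1 `CCS(=O)(=O)N1CCC2(CC1)OOC1(CCCCCC1)OO2`: > 100 ug/mL
- compound 2 `O=S(=O)(CCCCl)N1CCC2(CC1)OOC1(CCCCCC1)OO2`: > 100 ug/mL
- compound 3 `COc1ccc(S(=O)(=O)N2CCC3(CC2)OOC2(CCCCCC2)OO3)cc1`: > 100 ug/mL

Each entry is a limit and not a number. Compound 3 stands at > 100 ug/mL, which is a limit. The whole set sits at one ceiling: the limit of > 100 ug/mL in this assay, at which 3 of the 3 values shown sit.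

Compound 4 `O=S(=O)(c1ccc(F)cc1)N1CCC2(CC1)OOC1(CCCCCC1)OO2` has fluoro in place of methoxy on an aromatic carbon, para to a large group (fluoro in place of methoxy on an aromatic carbon).

The nearest evidence is a step that the two limits leave unreadable from compound 1 to compound 3 and a step that the two limits leave unreadable from compound 2 to compound 3, with a step that the two limits leave unreadable from compound 1 to compound 2 alongside. None of these gives a size. Compound 3 therefore offers only its limit as a reference, and no step beyond the scatter is expected in this assay, in either direction. The expected change is a step that the limit leaves unreadable from compound 3 to compound 4. For compound 4 the estimated value is 120 ug/mL, within an expected range of 60 ug/mL to 250 ug/mL.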

Compound 4, half-maximal cytotoxic concentration: > 100 ug/mL
Compound 4: no number, only a limit; the forecaster's own chance of this, stated with the estimate: 80%; the middle value does not contradict the limit.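

The steps from compound 1, compound 2 and compound 3 to compound 4 cannot be read, as every value is a limit and not a number: the limit of > 100 ug/mL in this assay, at which 4 of the 4 values shown sit.

The compounds shown leave open whether any change of group on the sulfonyl sulfur shifts the read-out in this assay.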